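Aryl enones and aminoketones at thyroid hormone receptor alpha

The source may report more compounds than this note shows. Statements on the series, on what has been measured and on what is new or still open speak of the compounds shown alone.

Measured so far:
compound 1 `CCCCCCc1ccc(C(=O)CCN2CCC(C(=O)OC)CC2)cc1` — 6300 nM
compound 2 `CCCCCCc1ccc(C(=O)CCN(CCCC)CCCC)cc1` — 6900 nM
compound 3 `C/C=C/C(=O)c1ccc(CCCCCCC)cc1` — 18900 nM

Three compounds have been run in an assay on isolated protein for displacement of a labelled ligand from thyroid hormone receptor alpha (Homo sapiens), read by fluorescence polarization; on this read-out higher numbers stand for weaker inhibition and lower numbers for stronger inhibition. Compound 1 gives 6300 nM and compound 2 gives 6900 nM; these two numbers sit within the scatter of each other, so no order can be drawn between them. Compound 3, the enone, gives 18900 nM, the highest number of the three: it stands beyond the scatter above compound 2 and above compound 1.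

Compound 4 `C=CC(=O)c1ccc(CCCCCCC)cc1` has not yet been measured in this assay. It differs from compound 3 in one place: vinyl in place of prop-1-en-1-yl on a carbonyl carbon. Within the data shown here, the chain that leaves and the chain that enters are both short, uncharged and carry no donors or acceptors, and no measured pair in the set isolates such a change, so there is no step to lean on. The expectation is that the step of a 1.1-fold higher number from compound 3 to compound 4 (0.02 log units; within the scatter) stays within the scatter, with no clear direction. Compound 4 is therefore estimated at 20000 nM, with a range from 7000 nM to 55000 nM.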

Compound 4, half-maximal inhibitory concentration: 23000 nM
Compound 4: the middle estimate sits 1.2-fold (0.06 log units) below what was measured, and the stated range covers the measured number.
By their numbers in this assay, from the lowest: compounds 1 and 2 (each within the scatter of the next); then compounds 3 and 4 (each within the scatter of the next).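

In this assay, among these compounds, this is the first pair that differs in one place, and vinyl in place of prop-1-en-1-yl on a carbonyl carbon gives a 1.2-fold higher number from compound 3 to compound 4 (0.09 log units; within the scatter). The chain of 3 heavy atoms and the chain of 2 heavy atoms, each with a double bond outside aromatic rings, therefore cannot be told apart at this position, and no order can be drawn between compound 3 and compound 4. Nothing in the data bears on the reason for this result.

On these data alone, whether an ethyl group, which lacks the double bond, a longer chain, an amine or a carboxylic acid on this carbonyl carbon would separate from these values remains open. Compound 1 and compound 2 each differ from both enones in more than one place, so the contribution of the amine-bearing chains also stays unresolved.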